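This account rests on a few compounds, and the source may have more. Where it says the series, first, only, none or still open, it means among the compounds named here.

Working notes on the series in an ADME assay on the whole organism (plasma, Rattus norvegicus) for protein binding, using cassette dosing, at a dose of 1 mg/kg; on this read-out lower numbers stand for a smaller free fraction and higher numbers for a larger free fraction. Of the compounds shown here, three have numbers so far. Going by the values given here, compound 1 `CC(C)Oc1ccc(/N=c2\[nH]c(=O)n(CC(C)(C)C(=O)O)c(=O)n2Cc2ccc(Cl)cc2)cc1Cl` gives 0.003 and compound 3 `CC(C)Oc1ccc(/N=c2\[nH]c(=O)n(C[C@H](C)C(=O)O)c(=O)n2Cc2ccc(Cl)cc2)cc1Cl` gives 0.003; the step of no change at the digits printed from compound 1 to compound 3 (within the scatter) is the only single-point comparison measured, and it concerns the chain on the ring nitrogen, not the aryl ether. Compound 2 `C[C@@H](Cn1c(=O)[nH]/c(=N\c2ccc(Oc3ccccn3)cc2)n(Cc2ccc(Cl)cc2)c1=O)C(=O)O` gives 0.01, the highest of the three numbers, beyond the scatter from both compound 1 and compound 3, which it exceeds by the same margin.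

Compound 4 `C[C@@H](Cn1c(=O)[nH]/c(=N\c2ccc(Oc3ccsn3)cc2)n(Cc2ccc(Cl)cc2)c1=O)C(=O)O` is not yet measured. It differs from compound 2 by 1,2-thiazol-3-yl in place of pyridin-2-yl on an oxygen on an aromatic ring. Among the compounds with values here, no measured step bears on this change: the one step in hand, no change at the digits printed from compound 1 to compound 3 (within the scatter), sits elsewhere on the molecule and was flat, and compound 1 and compound 3 differ from compound 2 in more than one place, so their gap to compound 2 cannot be assigned to the ether substituent. The step from compound 2 to compound 4 is therefore expected to be a 1.3-fold lower number from compound 2 to compound 4 (0.10 log units; within the scatter), within the scatter. The estimate for compound 4 is 0.008, with a range of 0.003 to 0.02.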

Compound 4, unbound fraction: 0.012
For compound 4 the middle estimate is 1.5-fold (0.18 log units) below the measured one; measured number inside the range.
By their numbers in this assay, from the lowest: compounds 1 and 3 (each within the scatter of the next); then compounds 2 and 4 (each within the scatter of the next).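

In this assay, going by these compounds alone, the step of a 1.2-fold higher number from compound 2 to compound 4 (0.08 log units; within the scatter) is the first measured change on an oxygen on an aromatic ring, which the flat step among the earlier compounds, on the chain at the ring nitrogen, could not address. With the rest of the molecule held constant, a five-membered aromatic ring with 2 hetero atoms and a six-membered aromatic ring with 1 hetero atom are not told apart at this place on this read-out, so (1,2-thiazol-3-yl)oxy is tolerated in place of (pyridin-2-yl)oxy. Nothing in hand explains why the two groups read alike.

Compound 1 and compound 3 differ from compound 2 and compound 4 in more than one place, so what separates the two pairs remains unassigned. As far as these compounds go, whether a methyl or a pyrimidin-2-yl on an oxygen on an aromatic ring would read the same also stays open.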